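A few compounds are considered here, and "the series" means these few. Any claim that something is new, unique, unknown or untested is made for them only; others in the source may bear on it.

Working notes on the sulfonamide series. Compound 1 `CCN(Cc1ccccc1)C(=O)C1CCN(S(=O)(=O)c2c[nH]cn2)CC1` stands only at a limit in a functional assay on CHO cells for positive allosteric modulation of muscarinic acetylcholine receptor M5 (Homo sapiens), read by calcium flux; on this read-out higher numbers stand for an effect only at larger amounts of compound and lower numbers for an effect already at smaller amounts: compound 1 gives > 10000 nM, which is a limit of the assay and not a number. Compound 2 `CCN(Cc1ccccc1)C(=O)C1CCN(S(=O)(=O)c2ccc(C)s2)CC1` likewise reaches only a limit in this assay, > 10000 nM; > 10000 nM (2 entries). Compound 3 `CCN(Cc1ccccc1)C(=O)C1CCN(S(=O)(=O)c2ccc3occc3c2)CC1` is the single member with a number, 2340 nM; 2400 nM (2 entries) in this assay, with close agreement between repeats as shown by the several entries of compound 3 in this assay, 2340 nM; 2400 nM (2 entries). Compound 4 `CCN(Cc1ccccc1)C(=O)C1CCN(S(=O)(=O)c2cccc3nsnc23)CC1` is not yet measured; it differs from compound 1 by a group of 9 heavy atoms (6 carbon, 2 nitrogen, 1 sulfur; one five-membered aromatic ring with 3 hetero atoms, one six-membered aromatic ring of carbon only) in place of a group of 5 heavy atoms (3 carbon, 2 nitrogen; one five-membered aromatic ring with 2 hetero atoms), on a sulfonyl sulfur. Going by the values given here, no measured step covers this change. Compound 3 carries the larger sulfonyl substituent among the measured members, and its value 2340 nM; 2400 nM (2 entries) guides the expectation. The expected step of an at least 3.3-fold lower number from compound 1 to compound 4 (0.52 log units; beyond the scatter) in this assay points toward a number rather than a limit. Compound 4 is estimated at 3000 nM, within the range 1000 nM to 10000 nM.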

Compound 4, half-maximal effective concentration: > 10000 nM
Compound 4 was reported as a limit (the forecaster's own chance of this, stated with the estimate: 35%); at least 3.3-fold (0.52 log units) between middle value and limit.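

Compound 1 and compound 4 both stand only at a limit, not at a number, so no step can be read between them. The compounds shown leave open how far the sulfonyl substituent change shifts the read-out.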